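Bromo to methyl in a series resting on limits

The source may report more compounds than this note shows. Statements on the series, on what has been measured and on what is new or still open speak of the compounds shown alone.

In an ADME assay on MT4 cells (Homo sapiens) for cytotoxicity, read by MTT assay, with a stated time of 4 days (a lower number here means that less compound is tolerated, a higher number that more compound is tolerated), compound 1 (`O=C(c1ccccc1)c1cc(Br)ccc1OCCn1ccc(=O)[nH]c1=O`) gives > 301000 nM, which is a limit and not a number. Compound 2 (`Cc1cc(C)cc(C(=O)c2cc(Cl)ccc2OCCn2cc(C)c(=O)[nH]c2=O)c1`) gives > 303000 nM, which is also a limit. Compound 3 (`Cc1cc(C)cc(C(=O)c2cc(Br)ccc2OCCn2ccc(=O)[nH]c2=O)c1`) gives > 282000 nM, again a limit. Compound 3 therefore has no exact standing in the series, and the two other values offer no exact number to compare it with.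

Compound 4 (`Cc1cc(C)cc(C(=O)c2cc(C)ccc2OCCn2ccc(=O)[nH]c2=O)c1`) has methyl in place of bromo on an aromatic carbon, meta to a large group and para to a large group: methyl in place of bromo on an aromatic carbon. For the measured compounds named here, the only measured step, a step that the two limits leave unreadable from compound 1 to compound 3, concerns another part of the structure and gives no size to carry over. Going by the values given here, no measured step covers the exchange of bromo for methyl.

The expectation rests on compound 3, whose value of > 282000 nM is a limit. In this assay, no step beyond the scatter is expected, and no direction can be assigned. The estimated change is a step that the limit leaves unreadable from compound 3 to compound 4. A report as a limit is the expected outcome for compound 4. The estimated value for compound 4 is 330000 nM, with an expected range from 150000 nM to 400000 nM.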

Compound 4, half-maximal cytotoxic concentration in the MT4 assay: 179000 nM
Compound 4: middle estimate off by 1.8-fold (0.27 log units), on the high side; low and high end bracket the measured number.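

Notes on the bromo to methyl exchange: in the MT4 assay methyl in place of bromo on an aromatic carbon, meta to a large group and para to a large group, gives an at least 1.5-fold lower number from compound 3 to compound 4 (0.19 log units; that floor lies within the scatter) and yields the only exact number among the compounds shown, although the floor of that step does not clear the scatter. In the MT4 assay compound 3 gives > 282000 nM as a limit, so one end of the step is not an exact number. In a physicochemical assay for solubility (a higher number here means a more soluble compound, a lower number a less soluble compound), compound 3 gives 1800 nM and compound 4 gives 28900 nM. The same exchange gives a large step in the physicochemical assay, where both ends are exact numbers: the measured solubility of compound 3, 1800 nM, and of compound 4, 28900 nM, a 16-fold higher number (1.21 log units; beyond the scatter).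

A methoxy group or an amine at this aromatic carbon would show whether the step in the physicochemical assay is tied to methyl or appears with other replacements for bromo. From the compounds shown here alone, in the MT4 assay the upper size of the step to compound 4 remains open, and the steps with limits at both ends cannot be read.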